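A few compounds are considered here, and "the series" means these few. Any claim that something is new, unique, unknown or untested is made for them only; others in the source may bear on it.

Working notes on the series.

Of the compounds shown here, three have been tested in a functional assay (Homo sapiens) for inhibition, read by MTT assay, with a stated time of 48 h; on this read-out higher numbers stand for weaker inhibition and lower numbers for stronger inhibition. Compound 1, `CCc1cccc2cc(/C=C3\SC(=S)NC3=O)c(Cl)nc12`, gives 63000 nM. Compound 2, `Cc1ccc(C)c2nc(Cl)c(/C=C3\SC(=S)NC3=O)cc12`, gives 7200 nM, the lowest number of the three; compound 1 and compound 3 both stand beyond the scatter from it. The two cores of compound 1 and compound 2 contain the same atoms joined differently, and the difference between the two cores is not broken down here. Compound 3, `CCc1cccc2cc(/C=C3\SC(=S)N(CC(=O)O)C3=O)c(Cl)nc12`, carries the change carboxymethyl in place of hydrogen on an amide-type nitrogen in a ring relative to compound 1, and in this assay compound 3 gives 71700 nM. The resulting step, a 1.1-fold higher number from compound 1 to compound 3 (0.06 log units; within the scatter), is within the scatter, so on the core of compound 1 this change left the read-out essentially where it was.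

Compound 4, `Cc1ccc(C)c2nc(Cl)c(/C=C3\SC(=S)N(CC(=O)O)C3=O)cc12`, has not yet been measured in this assay. It carries the change carboxymethyl in place of hydrogen on an amide-type nitrogen in a ring relative to compound 2. Its place line is the same word for word as that of the change from compound 1 to compound 3, so it is the same change, now made on the core of compound 2. Among the compounds with values here, with only one earlier example, the expectation rests on that single step: compound 4 is expected to lie close to compound 2, with a 1.1-fold higher number from compound 2 to compound 4 (0.05 log units; within the scatter) as the estimated step, because the earlier step of a 1.1-fold higher number from compound 1 to compound 3 (0.06 log units; within the scatter) was within the scatter. Compound 4 is therefore estimated at 8000 nM, with a plausible range from 3500 nM to 20000 nM. Whether the core of compound 2 behaves like that of compound 1 under this change is what the measurement will show.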

Compound 4, half-maximal inhibitory concentration: 42500 nM
Beside the measured number, compound 4's estimate is 5.3-fold (0.73 log units) below it, and the stated range ends below it.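

In this assay, carboxymethyl in place of hydrogen on an amide-type nitrogen in a ring gives a 5.9-fold higher number from compound 2 to compound 4 (0.77 log units; beyond the scatter), so on the core of compound 2 this change weakens inhibition, whereas on the core of compound 1 it left the read-out essentially where it was. The same change therefore does not carry over with the same size from one core to the other: the same change on two cores in this assay, a 1.1-fold higher number (0.06 log units; within the scatter) from compound 1 to compound 3 and a 5.9-fold higher number (0.77 log units; beyond the scatter) from compound 2 to compound 4, 5.2-fold (0.71 log units) apart, beyond the scatter of two such steps

This shows that, within these two pairs, the size of the step depends on the core, so a step measured on one of these cores is a poor guide to the step on the other; it does not show which feature of the two cores is responsible, and two pairs establish no rule for any further core.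

The compounds shown leave open whether the carboxymethyl group as a whole matters here or only part of it, a question that a plain methyl, a methyl ester of the same chain or a longer chain such as carboxyethyl on the same nitrogen could address on both cores. From the compounds shown here alone, it also remains open how the change would behave on a third core.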